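Trading a Furan for a Dimethylaminopyridine on the Thiazole

The compounds below may be only part of what the source reports. "The series", "measured", "known", "first", "only" and "open" are said of these compounds alone.

Compound 1 `O=C(O)Cc1sc(C(Cc2ccccc2)c2ccccc2)nc1-c1ccc(Cl)cc1`: 510 nM
Compound 2 `O=C(O)Cc1sc(C(c2ccccc2)c2ccc(F)c(F)c2)nc1-c1ccc(F)cc1`: 64 nM
Compound 3 `O=C(O)Cc1sc(C(c2ccc(F)cc2)c2ccc(F)cc2)nc1-c1ccco1`: 140 nM

Of the compounds shown here, three sharing one core have been tested in an in vitro functional assay on HEK285-7 cells for antagonist activity at prostaglandin D2 receptor 2 (Homo sapiens), read by BRET and beta-arrestin recruitment; a higher number here means a weaker inhibitor, a lower number a stronger inhibitor. Compound 3 gives 140 nM and holds the second highest of the three numbers. Compound 2 sits nearest to it with a lower number, a gap that is beyond the scatter; compound 1 lies furthest from it, with a higher number, also beyond the scatter. For the measured compounds named here, no single-point step between these measured compounds is available, so nothing more than their values can be said.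

Compound 4 `CN(C)c1cc(-c2nc(C(c3ccc(F)cc3)c3ccc(F)cc3)sc2CC(=O)O)ccn1` has not yet been measured in this assay. It departs from compound 3 in one place: 2-(dimethylamino)pyridin-4-yl in place of furan-2-yl on an aromatic carbon. Nothing measured here isolates this change, and the three values give no trend to lean on. The expectation is a step toward a lower number from compound 3 to compound 4, of a 1.8-fold lower number from compound 3 to compound 4 (0.24 log units; within the scatter), possibly no larger than the scatter. Compound 4 is estimated at 80 nM, within a range from 25 nM to 300 nM.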

Compound 4, half-maximal inhibitory concentration: > 100000 nM
Compound 4: only a limit was reported (the forecaster's own chance of this, stated with the estimate: 3%); at least 1200-fold (3.09 log units) between middle value and limit.
By their numbers in this assay, from the lowest: compound 2; then compound 3; then compound 1. At a limit, above all of these: compound 4.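

Compound 4 gives the first single-place comparison among these compounds: 2-(dimethylamino)pyridin-4-yl in place of furan-2-yl, on the aromatic carbon next to the ring nitrogen, produces an at least 710-fold higher number from compound 3 to compound 4 (2.85 log units; beyond the scatter) in this assay. In this assay, on these data alone, compound 4 gives > 100000 nM, which is a limit and not a number: the limit of > 100000 nM in this assay, at which 1 of the 4 values shown sits. This aromatic carbon therefore does not tolerate every aromatic group, and the true size of the step remains unknown beyond what the limit shows.

The step changes the ring and adds the dimethylamino group at once, so the compounds shown cannot say which of the two accounts for the loss. A plain pyridin-4-yl, or a pyridine carrying a methoxy group or a primary amine instead of dimethylamino, would separate these two changes.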